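Shared core series: phenol to difluorophenyl step

The source may hold more compounds than are shown below. What is called first, only, known or untested is meant among the compounds shown, and "the series" means these compounds.

compound 1 `O=C1C(=Cc2ccc(O)cc2)C(=O)N(c2ccc(Cl)cc2)N1c1ccc(Cl)cc1` — 19500 nM
compound 2 `COc1ccc(C=C2C(=O)N(c3ccc(Cl)cc3)N(c3ccc(Cl)cc3)C2=O)cc1` — a limit, > 128000 nM

For the measured compounds named here, in a functional assay on MGC-803 cells (Homo sapiens) for cytotoxicity, read by MTT assay, with a stated time of 72 h (on this read-out higher numbers stand for weaker inhibition and lower numbers for stronger inhibition), compound 1 gives 19500 nM, the only plain number in the set. For compound 2 this assay reports only a limit, > 128000 nM. Going by the values given here, the one measured step is an at least 6.5-fold higher number from compound 1 to compound 2 (0.81 log units; beyond the scatter), and it runs to the limit of > 128000 nM in this assay, at which 1 of the 2 values shown sits. Compound 3 `O=C1C(=Cc2ccc(F)cc2F)C(=O)N(c2ccc(Cl)cc2)N1c1ccc(Cl)cc1` carries 2,4-difluorophenyl in place of 4-hydroxyphenyl on a double-bonded chain carbon bound to a double-bonded ring carbon. Like the methylation in compound 2, this change takes away the phenolic hydrogen-bond donor, but it also removes the oxygen and brings in two fluorines, so the measured step is only a partial guide. For compound 3 a weakening in this assay is expected, a 3.1-fold higher number from compound 1 to compound 3 (0.49 log units; beyond the scatter), with a real chance that this assay again reports only a limit. Compound 3 is expected at 60000 nM, between 15000 nM and 200000 nM.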

Compound 3, half-maximal inhibitory concentration: 35700 nM
For compound 3 the middle estimate is 1.7-fold (0.23 log units) above the measured one; the range from low to high includes it.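

At this position, on a double-bonded chain carbon bound to a double-bonded ring carbon, the 4-hydroxyphenyl group can give way to 2,4-difluorophenyl, which has 0 hydrogen-bond donors, with only a small step in this assay: a 1.8-fold higher number from compound 1 to compound 3 (0.26 log units; within the scatter). Against the 4-methoxyphenyl group of compound 2, the same 2,4-difluorophenyl group gives an at least 3.5-fold lower number from compound 2 to compound 3 (0.55 log units; beyond the scatter), so the loss seen with compound 2 does not track the missing donor alone. The value for compound 2 is a limit and not a number, so that step has no fixed size: the limit of > 128000 nM in this assay, at which 1 of the 3 values shown sits.

The compounds shown leave open whether a single fluorine, as in 4-fluorophenyl, would sit at the level of compound 3. They also leave open how an amine or a carboxylic acid in place of the hydroxyl would compare with compound 1.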